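The source may report more compounds than this note shows. Statements on the series, on what has been measured and on what is new or still open speak of the compounds shown alone.

Measured so far in a functional assay on SK-OV-3 cells (Homo sapiens) for antiproliferative activity, read by MTT assay, with a stated time of 24 h; a lower number here means a stronger inhibitor, a higher number a weaker inhibitor:
compound 1 `COc1ccc(C(=O)/C=C/c2ccc(Br)cc2)c2c1C=CC(C)(C)O2` — compound 1 gives > 10000 nM, a limit of the assay and not a number.
compound 2 `COc1ccc(C(=O)/C=C/c2ccc(N(c3ccccc3)c3ccccc3)cc2)c2c1C=CC(C)(C)O2` — compound 2 gives > 10000 nM, likewise a limit.
compound 3 `COc1ccc(C(=O)/C=C/c2ccc([N+](=O)[O-])cc2)c2c1C=CC(C)(C)O2` — compound 3 gives 3420 nM.

Compound 1 stands at the limit of this assay, and no number is known for it. Compound 2 sits at the same limit, so the series holds (the limit of > 10000 nM in this assay, at which 2 of the 3 values shown sit). Compound 3 is the only one of the three with a measured number. Among the compounds with values here, the one step that touches compound 1 is an at least 2.9-fold lower number from compound 1 to compound 3 (0.46 log units; beyond the scatter).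

Compound 4 `COc1ccc(C(=O)/C=C/c2ccccc2)c2c1C=CC(C)(C)O2` differs from compound 1 by hydrogen in place of bromo on an aromatic carbon. Within the data shown here, no measured step replaces bromo with hydrogen, so the step from compound 1 to compound 4 rests only on what the three values show. The step to compound 3 shows that the number can move when the bromo is exchanged, but the entering group there was nitro, and compound 2, carrying a different substituent, remains at the limit. For hydrogen in place of bromo no movement beyond the scatter is expected in this assay, and the estimated step is a step that the limit leaves unreadable from compound 1 to compound 4. Compound 4 is therefore expected to give about 15000 nM in this assay, within a range from 5000 nM to 40000 nM. It is expected that the assay will most likely report a limit again for compound 4.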

Compound 4, half-maximal inhibitory concentration: > 10000 nM
Compound 4: a limit, no number; the forecaster's own chance of this, stated with the estimate: 70%; the middle value does not contradict the limit.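

Hydrogen in place of nitro at this position, on an aromatic carbon para to a large group, gives an at least 2.9-fold higher number from compound 3 to compound 4 (0.46 log units; beyond the scatter) in this assay. This sets the nitro compound apart from the unsubstituted phenyl as well as from the 4-bromophenyl compound, so removing the substituent altogether does not yield a measured number. Among the four compounds shown, only nitro at this position gives a number, while the bromo, diphenylamino and hydrogen compounds all stay at one limit: the limit of > 10000 nM in this assay, at which 3 of the 4 values shown sit.

No step can be read between compound 1 and compound 4, as both values are limits, and no order of the two follows from them. As far as these compounds go, it remains open whether the number of compound 3 is particular to nitro or would also appear with a nitrile, a trifluoromethyl, an amine or a carboxylic acid in the same place, and how far compound 1, compound 2 and compound 4 lie beyond the limit of the assay.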